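Moving from dimethyl to ethoxy on the piperazine aryl

The source may hold more compounds than are shown below. What is called first, only, known or untested is meant among the compounds shown, and "the series" means these compounds.

Compound 1 `Cc1nc(-c2ccccc2)c(C(=O)N2CCN(c3cccc(C)c3C)CC2)o1` is the strongest of the two numbered compounds in a functional assay on HL-60 cells (Homo sapiens) for inhibition, read by MTT assay, with a stated time of 72 h (a higher number here means a weaker inhibitor, a lower number a stronger inhibitor), where compound 1 gives 35 nM. The nearest numbered neighbour is compound 3 `CCc1nc(-c2ccc(C(C)C)cc2)c(C(=O)N2CCN(c3cccc(OC)c3)CC2)o1`, which in this assay gives 887 nM, a gap well beyond the scatter. Compound 2 `COc1cccc(N2CCN(C(=O)c3oc(C(F)(F)F)nc3-c3ccc(F)cc3)CC2)c1` returned no number in this assay and is recorded as "not active" (no number reported). Compound 4 `CCOc1cccc(N2CCN(C(=O)c3oc(C)nc3-c3ccccc3)CC2)c1` differs from compound 1 in one place: 3-ethoxyphenyl in place of 2,3-dimethylphenyl on an amine nitrogen in a ring. Going by the values given here, no measured pair shows this exact change, so the size of the step is open; given that compound 1 stands at 35 nM while compound 3 sits at 887 nM, a weakening beyond the scatter is expected. Compound 4 is therefore estimated at 300 nM, within 60 nM to 1500 nM, a step of an 8.6-fold higher number from compound 1 to compound 4 (0.93 log units; beyond the scatter).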

Compound 4, half-maximal inhibitory concentration: 151 nM
Beside the measured number, compound 4's estimate is 2.0-fold (0.30 log units) above it; the measured number falls inside the stated range.
By their numbers in this assay, from the lowest: compound 1; then compound 4; then compound 3.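

Going by these compounds alone, replacing 2,3-dimethylphenyl with 3-ethoxyphenyl on the amine nitrogen in a ring gives the first single-place step at this position in this assay: a 4.3-fold higher number from compound 1 to compound 4 (0.63 log units; beyond the scatter), modest but beyond the scatter. The position therefore responds to this change without losing activity, as compound 4 still gives 151 nM. Nothing on record accounts for the step. The compounds shown leave open whether the loss comes from removing the two methyl groups or from adding the ethoxy group, as this one change does both. As far as these compounds go, how a propoxy chain or an amine on that aryl ring would read also remains open.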